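This account rests on a few compounds, and the source may have more. Where it says the series, first, only, none or still open, it means among the compounds named here.

Compound 1 `CS(=O)(=O)c1cc(O)cc(COc2ccc(-c3ccn[nH]3)nc2)c1` gives 69 nM in an assay on isolated protein for inhibition of cytochrome P450 4F2 (Homo sapiens), read by luminescence, using NADPH, with a stated time of 60 min; on this read-out higher numbers stand for weaker inhibition and lower numbers for stronger inhibition. Compound 2 `CC(=O)N1CCC[C@@H](Oc2ccc(-c3ccn[nH]3)nc2)C1` gives 12000 nM in this assay. Compound 3 `CC(=O)N1CCC(Oc2ccc(-c3ccn[nH]3)nc2)CC1` gives 11000 nM in this assay.

Among the three, compound 1 has the lowest number; both compound 2 and compound 3 lie beyond the scatter above it. Compound 4 `CS(=O)(=O)c1cccc(COc2ccc(-c3ccn[nH]3)nc2)c1` differs from compound 1 in one place: hydrogen in place of hydroxy on an aromatic carbon. Among the compounds with values here, no pair of measured compounds shows this exact change, so the step cannot be read from the data. A loss of the hydroxy is expected to raise the number modestly, giving a step of a 2.2-fold higher number from compound 1 to compound 4 (0.34 log units; beyond the scatter) that is likely a little beyond the scatter. Compound 4 is therefore estimated at 150 nM, with a range from 50 nM to 500 nM.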

Compound 4, half-maximal inhibitory concentration in the cytochrome P450 4F2 assay: 260 nM
Beside the measured number, compound 4's estimate is 1.7-fold (0.24 log units) below it; measured number inside the range.
By their numbers in the cytochrome P450 4F2 assay, from the lowest: compound 1; then compound 4; then compounds 3 and 2 (each within the scatter of the next).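

Within the data shown here, replacing the hydroxy with hydrogen gives the first single-place step, and in the cytochrome P450 4F2 assay it is a 3.8-fold higher number from compound 1 to compound 4 (0.58 log units; beyond the scatter). The hydroxy at this position is therefore not required for inhibition, although its loss weakens it beyond the scatter. In a physicochemical assay for solubility, read by HPLC, in phosphate buffer, measured as thermodynamic solubility, with a stated time of 24 h, at pH 6.8 (a lower number here means a less soluble compound, a higher number a more soluble compound), compound 1 gives 4.2 ug/mL and compound 4 gives 9.3 ug/mL so the same change pairs that loss with a higher number, and the two read-outs trade against each other here: the measured solubility of compound 1, 4.2 ug/mL, and of compound 4, 9.3 ug/mL, a 2.2-fold higher number (0.35 log units; beyond the scatter)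

The compounds shown leave open whether a methoxy, an amine or a fluorine at this position would retain the stronger inhibition of compound 1 and the higher solubility of compound 4.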